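Methoxy removal on the fused ring of compound 2

The compounds below may be only part of what the source reports. "The series", "measured", "known", "first", "only" and "open" are said of these compounds alone.

Two compounds of the series have been run in an assay on HEK293 cells for displacement of a labelled ligand from 5-hydroxytryptamine receptor 7 (Rattus norvegicus); on this read-out higher numbers stand for weaker inhibition and lower numbers for stronger inhibition. Compound 1 `COc1ccc2c(c1)CCCC2NC(=O)CCCN1CCN(c2ccccc2OC)CC1` gives 186 nM in this assay. Compound 2 `COc1ccccc1N1CCN(CCCC(=O)NC2CCCc3cccc(OC)c32)CC1`, which carries its methoxy group on the other side of the fused ring system, gives 154 nM in this assay. Compound 2 thus stands at the lowest of the two numbers, yet its gap to compound 1 lies within the scatter of repeated measurements, so the two cannot be told apart on this read-out.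

Compound 3 `COc1ccccc1N1CCN(CCCC(=O)NC2CCCc3ccccc32)CC1` has not yet been measured. It differs from compound 2 in one place: hydrogen in place of methoxy on an aromatic carbon. The group is taken off an aromatic carbon of the six-membered carbon-only ring that forms part of the fused two-ring system, ortho to a fused ring and meta to a fused ring.

Going by the values given here, no measured pair shows this change, so its size is unknown. Given that compound 1 and compound 2, which place the methoxy differently, stay within the scatter of each other, the expectation is a step from compound 2 to compound 3 that is small in this assay, if anything toward a slightly higher number, a 1.4-fold higher number from compound 2 to compound 3 (0.15 log units; within the scatter). Compound 3 is therefore estimated at 220 nM in this assay, with a range from 80 nM to 600 nM.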

Compound 3, inhibition constant: 92 nM
Compound 3: middle estimate off by 2.4-fold (0.38 log units), on the high side, and the stated range covers the measured number.
By their numbers in this assay, from the lowest: compounds 3, 2 and 1 (each within the scatter of the next, the first and the last beyond it).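

In this assay, hydrogen in place of methoxy gives a 1.7-fold lower number from compound 2 to compound 3 (0.22 log units; within the scatter), and from the other methoxy placement the same exchange gives a 2.0-fold lower number from compound 1 to compound 3 (0.31 log units; beyond the scatter); the first step lies within the scatter, and the second lies just beyond it and is modest. Going by these compounds alone, the methoxy on this six-membered aromatic ring is therefore not required to hold the number in this range, and neither methoxy placement gives a number lower than that of the compound carrying hydrogen, which is the first thing the earlier pair could not show. No measurement at hand speaks to why the numbers fall this way.

The compounds shown carry only methoxy or hydrogen on this ring, so it remains open whether a chlorine, a hydroxyl or an ethoxy on this aromatic carbon would move the number beyond the scatter from compound 3 in either direction. As far as these compounds go, it also remains open whether the same exchange would give a similar step with a shorter or longer chain between the amide carbonyl and the piperazine.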